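A few compounds are considered here, and "the series" means these few. Any claim that something is new, unique, unknown or untested is made for them only; others in the source may bear on it.

Working notes on the series. All four compounds share one core and differ only in the group on the carbonyl carbon of the amide. Compound 1 `CN1[C@@H]2c3[nH]c4ccccc4c3C[C@H]1[C@H](C#N)N1[C@@H](CNC(=O)c3cccc4c3CCCC4)c3[nH]c4ccccc4c3C[C@@H]21` gives 540 nM in a functional assay on HepG2 cells (Homo sapiens) for cytotoxicity, read by MTT assay, with a stated time of 72 h; on this read-out higher numbers stand for weaker inhibition and lower numbers for stronger inhibition. Compound 2 `CN1[C@@H]2c3[nH]c4ccccc4c3C[C@H]1[C@H](C#N)N1[C@@H](CNC(=O)c3cc4ccccc4o3)c3[nH]c4ccccc4c3C[C@@H]21` gives 280 nM in this assay, and compound 3 `CN1[C@@H]2c3[nH]c4ccccc4c3C[C@H]1[C@H](C#N)N1[C@@H](CNC(=O)c3cc4ccccc4[nH]3)c3[nH]c4ccccc4c3C[C@@H]21` gives 440 nM in this assay. The three steps among them are a 1.9-fold lower number from compound 1 to compound 2 (0.29 log units; within the scatter), a 1.2-fold lower number from compound 1 to compound 3 (0.09 log units; within the scatter) and a 1.6-fold higher number from compound 2 to compound 3 (0.20 log units; within the scatter). On the numbers shown compound 3 sits with compound 1 and compound 2 inside the scatter, and none of the three groups on the carbonyl carbon can be told apart on this read-out.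

Compound 4 `CN1[C@@H]2c3[nH]c4ccccc4c3C[C@H]1[C@H](C#N)N1[C@@H](CNC(=O)/C=C/c3ccccc3)c3[nH]c4ccccc4c3C[C@@H]21` is not yet measured. It differs from compound 3 in one place: 2-phenylethenyl in place of 1H-indol-2-yl on a carbonyl carbon. Among the compounds with values here, no measured step covers a group without a second ring at this position. Within the data shown here, the steps that bear on the change, a 1.2-fold lower number from compound 1 to compound 3 (0.09 log units; within the scatter) and a 1.6-fold higher number from compound 2 to compound 3 (0.20 log units; within the scatter), show only that exchanging one aromatic group for another on the carbonyl carbon left this assay within the scatter. The step from compound 3 to compound 4 in this assay is therefore expected to be no larger than the scatter, a 1.0-fold higher number from compound 3 to compound 4 (0.01 log units; within the scatter). Among the measured compounds shown here, no measured compound carries 2-phenylethenyl, so the allowance is kept wide. Compound 4 is estimated at 450 nM, within 150 nM to 1500 nM.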

Compound 4, half-maximal inhibitory concentration: 470 nM
Compound 4: middle estimate off by 1.0-fold (0.02 log units), on the low side; measured number inside the range.
By their numbers in this assay, from the lowest: compounds 2, 3, 4 and 1 (each within the scatter of the next).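

In this assay the exchange of 1H-indol-2-yl for 2-phenylethenyl on a carbonyl carbon gives a 1.1-fold higher number from compound 3 to compound 4 (0.03 log units; within the scatter) and so stays within the scatter, which extends the flat picture to a group with one six-membered aromatic ring, a double bond outside aromatic rings and no hydrogen-bond donor. The other two new steps agree, with a 1.7-fold higher number from compound 2 to compound 4 (0.22 log units; within the scatter) and a 1.1-fold lower number from compound 1 to compound 4 (0.06 log units; within the scatter) both within the scatter, so on this read-out neither a fused second ring nor the hydrogen-bond donor of 1H-indol-2-yl is needed among these four compounds for a value in the same range as the rest of the series. No measurement at hand gives a reason for this lack of separation.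

Still open, as far as these compounds go, is whether any group on this carbonyl carbon carrying no aromatic ring, such as a butyl chain, a piperidine or a carboxylic acid, would give a step beyond the scatter. Also open, from the compounds shown here alone, is what the double bond of 2-phenylethenyl contributes, a question that the saturated 2-phenylethyl group would address.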